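The source may report more compounds than this note shows. Statements on the series, on what has been measured and on what is new or still open speak of the compounds shown alone.

Compound 1 `NS(=O)(=O)c1ccc(N/C(S)=N\c2ccnc3cc(C(F)(F)F)ccc23)cc1` gives 36600 nM in a functional assay on HeLa cells (Homo sapiens) for antiproliferative activity, read by sulforhodamine B assay, with a stated time of 48 h; on this read-out higher numbers stand for weaker inhibition and lower numbers for stronger inhibition.
Compound 2 `O=S(=O)(Nc1ccccn1)c1ccc(N/C(S)=N\c2ccnc3cc(C(F)(F)F)ccc23)cc1` gives 68800 nM in this assay.
Compound 3 `Cc1cc(C)nc(NS(=O)(=O)c2ccc(N/C(S)=N\c3ccnc4cc(C(F)(F)F)ccc34)cc2)n1` gives 33000 nM in this assay.

Compound 3 has the lowest of the three numbers, but its gap to compound 1 lies within the scatter, so the two cannot be told apart; only compound 2 stands apart, with a 2.1-fold lower number from compound 2 to compound 3 (0.32 log units; beyond the scatter). Compound 4 `COc1cc(NS(=O)(=O)c2ccc(N/C(S)=N\c3ccnc4cc(C(F)(F)F)ccc34)cc2)nc(OC)n1` has not been measured. It differs from compound 3 by 2,6-dimethoxypyrimidin-4-yl in place of 4,6-dimethylpyrimidin-2-yl on a sulfonamide nitrogen. Among the measured compounds shown here, the steps that bear on this change, both of which swap the group on the sulfonamide nitrogen, are a 1.1-fold lower number from compound 1 to compound 3 (0.04 log units; within the scatter) and a 2.1-fold lower number from compound 2 to compound 3 (0.32 log units; beyond the scatter); neither moved the number far. The step from compound 3 to compound 4 is therefore expected to stay within the scatter, a 1.1-fold higher number from compound 3 to compound 4 (0.03 log units; within the scatter). Compound 4 is estimated at 35000 nM, with a likely range from 15000 nM to 80000 nM.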

Compound 4, half-maximal inhibitory concentration: 53800 nM
Compound 4: the middle estimate sits 1.5-fold (0.19 log units) below what was measured; low and high end bracket the measured number.
By their numbers in this assay, from the lowest: compounds 3, 1, 4 and 2 (each within the scatter of the next, the first and the last beyond it).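

In this assay, the 2,6-dimethoxypyrimidin-4-yl group, with 10 heavy atoms in place of 8, stays within the scatter of every earlier group on the sulfonamide nitrogen: a 1.6-fold higher number from compound 3 to compound 4 (0.21 log units; within the scatter), a 1.3-fold lower number from compound 2 to compound 4 (0.11 log units; within the scatter) and a 1.5-fold higher number from compound 1 to compound 4 (0.17 log units; within the scatter). This position therefore accepts hydrogen and three different aromatic rings with little change, the one exception being the gap between compounds 2 and 3. No measurement here explains this result. On these data alone, whether a non-aromatic group on this nitrogen, such as a carboxylic acid, an amine or a longer alkyl chain, would move the number further remains open.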